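The compounds below may be only part of what the source reports. "The series", "measured", "known", "first", "only" and "open" are said of these compounds alone.

Working notes on the series. Of the compounds shown here, two have been measured in a functional assay on A549 cells (Homo sapiens) for inhibition, read by MTT assay, with a stated time of 24 h; a lower number here means a stronger inhibitor, a higher number a weaker inhibitor. Compound 1 `CCOC(=O)C1=Cc2ccccc2OC1(OCc1cn(-c2ccc(F)cc2)nn1)C(F)(F)F` gives 7300 nM in this assay. For compound 2 `CCOC(=O)C1=Cc2ccccc2OC1(OCc1cn(-c2cccc(C(F)(F)F)c2)nn1)C(F)(F)F` this assay returns only a limit, > 150000 nM, and no number. For the measured compounds named here, the one step measured so far, an at least 20-fold higher number from compound 1 to compound 2 (1.31 log units; beyond the scatter), is thus a floor on the loss rather than a full value, because one of the two values sits at the limit of > 150000 nM in this assay, at which 1 of the 2 values shown sits.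

Compound 3 `CCOC(=O)C1=Cc2ccccc2OC1(OCc1cn(-c2ccc([N+](=O)[O-])cc2)nn1)C(F)(F)F` has not been measured. Relative to compound 2 the change is 4-nitrophenyl in place of 3-(trifluoromethyl)phenyl on an aromatic nitrogen. Going by the values given here, the only measured step that bears on this change is the one from compound 1 to compound 2, which was large and in the weakening direction on exchanging 4-fluorophenyl for 3-(trifluoromethyl)phenyl. Among the compounds with values here, compound 3 carries a 4-nitrophenyl rather than either of those groups, so the single measured step gives no direct guide, and a value anywhere between that of compound 1 and the limit of compound 2 is plausible. Compound 3 is expected near 30000 nM, with a range of 5000 nM to 150000 nM. For compound 3 this corresponds to an estimated step of an at least 5.0-fold lower number from compound 2 to compound 3 (0.69 log units; beyond the scatter).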

Compound 3, half-maximal inhibitory concentration: > 150000 nM
Compound 3: a limit, no number; the forecaster's own chance of this, stated with the estimate: 35%; middle value at least 5.0-fold (0.69 log units) away from the limit.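

In this assay, nitro in place of fluoro on an aromatic carbon gives an at least 20-fold higher number from compound 1 to compound 3 (1.31 log units; beyond the scatter). The large loss is therefore not confined to the 3-(trifluoromethyl)phenyl group: two different replacements of 4-fluorophenyl on the aromatic nitrogen both lose the measurable number, and of the three aryl groups shown only 4-fluorophenyl retains one. The step from compound 2 to compound 3 cannot be read, and compound 2 and compound 3 cannot be ranked against each other, because each carries a limit of the assay and not a number: the limit of > 150000 nM in this assay, at which 2 of the 3 values shown sit.

The compounds shown leave open whether the activity of compound 1 depends on fluoro itself, or whether an unsubstituted phenyl, 4-chlorophenyl or 4-methoxyphenyl on the same aromatic nitrogen would also give a measurable number in this assay. Also open, from the compounds shown here alone, is whether the place of the ring substituent matters, a question that a 3-fluorophenyl group on the same nitrogen would address directly.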